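The source may report more compounds than this note shows. Statements on the series, on what has been measured and on what is new or still open speak of the compounds shown alone.

Measured in a functional assay on MCF7 cells (Homo sapiens) for inhibition, read by MTT assay, with a stated time of 48 h, tested at 10 uM; a lower number here means less inhibition of growth, a higher number more inhibition of growth at the concentration tested:
compound 1 `COc1ccc(C(=O)/C=C/c2ccc(OCc3cn(Cc4ccc(F)cc4)nn3)cc2)cc1` gives 15%
compound 2 `O=C(/C=C/c1ccc(OCc2cn(Cc3ccccc3F)nn2)cc1)c1ccc([N+](=O)[O-])cc1` gives 33%
compound 3 `O=C(/C=C/c1ccc(OCc2cn(Cc3cccc(F)c3)nn2)cc1)c1ccc([N+](=O)[O-])cc1` gives 30%

Compound 3 stands second highest of the three numbers. Compound 2 is nearest, and the step of a number 3 percentage points lower from compound 2 to compound 3 (within the scatter) lies within the scatter. Compound 1 is furthest, beyond the scatter, but it differs from compound 3 in more than one place, so its value only shows that a 4-fluorobenzyl group occurs in a weakly inhibiting compound.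

Compound 4 `O=C(/C=C/c1ccc(OCc2cn(Cc3ccc(F)cc3)nn2)cc1)c1ccc([N+](=O)[O-])cc1` differs from compound 3 by 4-fluorophenyl in place of 3-fluorophenyl on a saturated chain carbon bound to an aromatic nitrogen. For the measured compounds named here, the one step that bears on this change, a number 3 percentage points lower from compound 2 to compound 3 (within the scatter), stayed within the scatter. The step of no change at the digits printed from compound 3 to compound 4 (within the scatter) is therefore expected to stay within the scatter as well. Compound 4 is estimated at 30% in this assay, with a range from 18% to 42%.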

Compound 4, percent growth inhibition at one concentration: 38%
Estimate against measurement, compound 4: 8 percentage points below, and the stated range covers the measured number.
By their numbers in this assay, from the lowest: compound 1; then compounds 3, 2 and 4 (each within the scatter of the next).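

In this assay, with the nitro group held, the fluorine placements do not separate: a number 8 percentage points higher from compound 3 to compound 4 (within the scatter) and a number 5 percentage points higher from compound 2 to compound 4 (within the scatter) complete the set of 2-fluorophenyl, 3-fluorophenyl and 4-fluorophenyl on a saturated chain carbon bound to an aromatic nitrogen. For the compounds shown here, with 4-fluorobenzyl held, nitro in place of methoxy on an aromatic carbon gives a number 23 percentage points higher from compound 1 to compound 4 (beyond the scatter) and is the first one-place step beyond the scatter. No available measurement accounts for this step.

That step rests on a single pair of compounds. Going by these compounds, whether an amine or a carboxylic acid on that aromatic carbon would match nitro, and how unsubstituted benzyl would compare with the fluorobenzyl groups, remain open.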